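The compounds below may be only part of what the source reports. "The series", "measured", "known", "first", "only" and "open" are said of these compounds alone.

Measured in a functional assay on Ishikawa cells (Homo sapiens) for antiproliferative activity, read by CCK-8 assay, with a stated time of 48 h; on this read-out lower numbers stand for stronger inhibition and higher numbers for weaker inhibition:
Compound 1 `C=C(C)C(=O)NCCOc1ccc(Oc2c(-c3ccc(F)cc3)sc3cc(O)ccc23)cc1`: > 25000 nM (a limit)
Compound 2 `C/C=C/C(=O)NCCOc1ccc(Oc2c(-c3ccc(F)cc3)sc3cc(O)ccc23)cc1`: 12400 nM

Going by the values given here, compound 2 gives the only number so far. For compound 1 the result is only (the limit of > 25000 nM in this assay, at which 1 of the 2 values shown sits).

The next compound to be read is compound 3 `O=C(/C=C/CNCCOc1ccc(Oc2c(-c3ccc(F)cc3)sc3cc(O)ccc23)cc1)N1CCC1`. The change is 3-((azetidin-1-yl)carbonyl)prop-2-en-1-yl in place of (prop-1-en-1-yl)carbonyl on an amine nitrogen. The entering 3-((azetidin-1-yl)carbonyl)prop-2-en-1-yl carries one four-membered non-aromatic ring with 1 hetero atom.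

Among the compounds with values here, one measured step bears on this: an at least 2.0-fold lower number from compound 1 to compound 2 (0.30 log units; that floor lies within the scatter). Its floor lies within the scatter, and it swaps a different group, so it gives only weak guidance and sets no firm direction. In this assay no clear move is therefore expected, and the estimated step is a 1.6-fold lower number from compound 2 to compound 3 (0.19 log units; within the scatter). For compound 3 the expected value is 8000 nM, with an estimated range of 1500 nM to 25000 nM.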

Compound 3, half-maximal inhibitory concentration: 6560 nM
Compound 3: the middle estimate sits 1.2-fold (0.09 log units) above what was measured; the range from low to high includes it.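

In this assay, 3-((azetidin-1-yl)carbonyl)prop-2-en-1-yl in place of (prop-1-en-1-yl)carbonyl on the amine nitrogen gives a 1.9-fold lower number from compound 2 to compound 3 (0.28 log units; within the scatter), so this position accepts the larger group with its four-membered ring without a step that can be read beyond the scatter. Going by these compounds alone, the same entering group in place of (1-methylethenyl)carbonyl gives an at least 3.8-fold lower number from compound 1 to compound 3 (0.58 log units; beyond the scatter), the first step beyond the scatter. Compound 1 is a limit of the assay, so this step gives only a floor: the limit of > 25000 nM in this assay, at which 1 of the 3 values shown sits.

From the compounds shown here alone, it remains open whether the azetidine ring itself matters, which a pyrrolidine or a dimethylamine amide at the same place would test. Also open, going by these compounds, is the role of the chain's double bond, which a saturated butanamide chain on the same nitrogen would address.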